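Cytotoxicity Outlook for the Allyl Ether of Compound 3

The source may hold more compounds than are shown below. What is called first, only, known or untested is meant among the compounds shown, and "the series" means these compounds.

Compound 1 `Oc1ccc(-c2nc3c(NC4CCCC4)cccn3c2-c2ccnc(NC3CCCC3)n2)cc1` — > 40000 nM (a limit)
Compound 2 `C=CCOc1ccc(-c2nc3c(NC4CCCC4)cccn3c2-c2ccnc(NC3CCCC3)n2)cc1` — > 40000 nM (a limit)
Compound 3 `Oc1cccc(-c2nc3c(NC4CCCC4)cccn3c2-c2ccnc(NC3CCCC3)n2)c1` — > 40000 nM (a limit)

In an ADME assay on Vero cells (Chlorocebus sabaeus) for cytotoxicity (on this read-out higher numbers stand for lower toxicity in this test and lower numbers for higher toxicity in this test), compound 3 reaches only the limit of the assay, > 40000 nM. Compounds 1 and 2 sit at the same limit, so (the limit of > 40000 nM in this assay, at which 3 of the 3 values shown sit). Compound 4 `C=CCOc1cccc(-c2nc3c(NC4CCCC4)cccn3c2-c2ccnc(NC3CCCC3)n2)c1` differs from compound 3 by allyl in place of hydrogen on an oxygen on an aromatic ring. Within the data shown here, two measured steps bear on this change: a step that the two limits leave unreadable from compound 1 to compound 2, the same exchange carried out on the 4-hydroxyphenyl ring, and a step that the two limits leave unreadable from compound 2 to compound 3. Both are unreadable; neither gives a direction or a size for the change. The expected step is a step that the limit leaves unreadable from compound 3 to compound 4, that is, nothing beyond the scatter, with compound 4 most likely staying at the limit. Compound 4 is estimated at 60000 nM, with a range from 30000 nM to 150000 nM.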

Compound 4, half-maximal cytotoxic concentration: > 40000 nM
Compound 4: a limit, no number (the forecaster's own chance of this, stated with the estimate: 85%); the middle value lies beyond the limit too.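

Among these compounds, compound 4 gives only a limit, as do compound 1, compound 2 and compound 3, so no step to compound 4 can be read in this assay. The compounds shown leave open whether allyl in place of hydrogen changes anything beyond that limit: the limit of > 40000 nM in this assay, at which 4 of the 4 values shown sit.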